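The compounds below may be only part of what the source reports. "The series", "measured", "known", "first", "only" and "open" are said of these compounds alone.

In a functional assay on MCF7 cells (Homo sapiens) for inhibition, read by MTT assay, with a stated time of 72 h (a lower number here means a stronger inhibitor, a higher number a weaker inhibitor), compound 1 (`COc1cc(NC(C)CCCNC(=O)Nc2cccc(Cl)c2)c2ncccc2c1`) gives 11000 nM and compound 2 (`COc1cc(NC(C)CCCNC(=O)Nc2ccc(F)cc2)c2ncccc2c1`) gives 26000 nM, the higher of the two numbers. Compound 3 (`COc1cc(NC(C)CCCNC(=O)NNC(=O)Nc2ccc(Br)cc2)c2ncccc2c1`) has ((4-bromophenyl)carbamoyl)amino in place of 4-fluorophenyl on an amide-type nitrogen. Among the compounds with values here, the only measured step, a 2.4-fold higher number from compound 1 to compound 2 (0.37 log units; beyond the scatter), is modest and exchanges one halogen-bearing phenyl group for another, so it bears only partly on this change. Within the data shown here, no measured compound carries the longer group, so the expectation is loose. The estimated change is a 2.2-fold lower number from compound 2 to compound 3 (0.34 log units; beyond the scatter), a modest move toward a lower number. For compound 3, the estimated value is 12000 nM, with an expected range of 2000 nM to 60000 nM.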

Compound 3, half-maximal inhibitory concentration: 100 nM
Compound 3: the middle estimate sits 120-fold (2.08 log units) above what was measured; the measured number lies below the stated range.
By their numbers in this assay, from the lowest: compound 3; then compound 1; then compound 2.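

In this assay, placing ((4-bromophenyl)carbamoyl)amino on the amide-type nitrogen gives a 260-fold lower number from compound 2 to compound 3 (2.41 log units; beyond the scatter) and a 110-fold lower number from compound 1 to compound 3 (2.04 log units; beyond the scatter). Both steps are large, whereas the earlier exchange of one halogen-bearing phenyl group for another was modest, so this position can respond far more strongly than that first step suggested. Nothing available explains the jump. From the compounds shown here alone, the bromine and the added carbamoyl-amino link enter together, so their separate contributions remain open, as does the effect of an unsubstituted phenyl ring or a longer chain at this place.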